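Chloro Added to Two Cores: Cytotoxicity Estimated

The source may hold more compounds than are shown below. What is called first, only, known or untested is meant among the compounds shown, and "the series" means these compounds.

Measured compounds in a functional assay on A549 cells (Homo sapiens) for cytotoxicity, read by MTT assay, with a stated time of 48 h; on this read-out higher numbers stand for weaker inhibition and lower numbers for stronger inhibition:
Compound 1 `Cc1[nH]c2ccc([N+](=O)[O-])cc2c1C1(c2c(C)[nH]c3ccc([N+](=O)[O-])cc23)C(=O)Nc2ccccc21` gives 890 nM.
Compound 2 `COC(=O)c1ccc2[nH]cc(C3(c4c[nH]c5ccc(C(=O)OC)cc45)C(=O)Nc4ccccc43)c2c1` gives 750 nM.
Compound 3 `Cc1[nH]c2ccc([N+](=O)[O-])cc2c1C1(c2c(C)[nH]c3ccc([N+](=O)[O-])cc23)C(=O)Nc2ccc(Cl)cc21` gives 69400 nM.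

Compound 1 and compound 2 share a spiro arrangement but differ in the groups on their outer rings; that difference between the two cores is not broken down here. Their values lie within the usual scatter, so neither can be called stronger.

Compound 3 arises from compound 1 by one change, (chloro in place of hydrogen on an aromatic carbon), and the result is a 78-fold higher number from compound 1 to compound 3 (1.89 log units; beyond the scatter), a large weakening. Compound 4 `COC(=O)c1ccc2[nH]cc(C3(c4c[nH]c5ccc(C(=O)OC)cc45)C(=O)Nc4ccc(Cl)cc43)c2c1` arises from compound 2 by the same change, (chloro in place of hydrogen on an aromatic carbon), at a place described in identical terms.

Among the compounds with values here, because the only precedent is a 78-fold higher number from compound 1 to compound 3 (1.89 log units; beyond the scatter), a weakening of similar size is expected, a 60-fold higher number from compound 2 to compound 4 (1.78 log units; beyond the scatter), though a single example leaves the size uncertain. Compound 4 is therefore estimated at 45000 nM, most likely between 8000 nM and 200000 nM in this assay.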

Compound 4, half-maximal inhibitory concentration: 71500 nM
Compound 4: the middle estimate sits 1.6-fold (0.20 log units) below what was measured; measured number inside the range.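

In this assay, putting chloro in place of hydrogen on an aromatic carbon gives a 95-fold higher number from compound 2 to compound 4 (1.98 log units; beyond the scatter), a large weakening on the second core. Set beside the earlier step, the change carries over from one core to the other at much the same size: the same change on two cores in this assay, a 78-fold higher number (1.89 log units; beyond the scatter) from compound 1 to compound 3 and a 95-fold higher number (1.98 log units; beyond the scatter) from compound 2 to compound 4, 1.2-fold (0.09 log units) apart, within the scatter of two such steps. This shows the same large weakening on these two cores only; it does not show why chloro has this effect, or that it would have the same effect on any other core in the series.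

The compounds shown leave open whether another group at this place, such as fluoro, methoxy or an amine, would weaken inhibition as much as chloro. Also open, on these data alone, is what chloro would do on a different carbon of the same ring.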